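Adding a Fluorine: Clearance Expected to Hold Steady

The compounds below may be only part of what the source reports. "The series", "measured", "known", "first", "only" and "open" are said of these compounds alone.

In an ADME assay on microsomes from liver (Rattus norvegicus, strain Wistar) for metabolic stability, tested at 2.5 uM (a higher number here means faster removal of the compound, a lower number slower removal), compound 2 `Clc1ccc(Cn2nnc3c(Br)cccc32)cc1` gives 2.2 mL/min/g. Going by the values given here, the only other compound measured, compound 1 `Fc1ccccc1Cn1nnc2c(Br)cccc21`, gives 1.8 mL/min/g in this assay, and the two numbers lie within the usual scatter of each other, so neither can be said to be removed faster than the other. Compound 3 `Fc1cc(Cl)ccc1Cn1nnc2c(Br)cccc21` is not yet measured. It differs from compound 2 in one place: fluoro in place of hydrogen on an aromatic carbon. Among the compounds with values here, with no measured step between compounds to lean on, the number for compound 3 is expected to stay close to that of compound 2, so the step of no change at the digits printed from compound 2 to compound 3 (within the scatter) is expected to fall within the scatter. The estimate for compound 3 is 2.2 mL/min/g, with a range from 1.3 mL/min/g to 3.8 mL/min/g.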

Compound 3, intrinsic clearance in a liver preparation (reported as CLH), per the amount of preparation that the assay uses: 3.8 mL/min/g
Compound 3: the middle estimate sits 1.7-fold (0.24 log units) below what was measured; measured number inside the range.
By their numbers in this assay, from the lowest: compounds 1, 2 and 3 (each within the scatter of the next, the first and the last beyond it).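

In this assay, fluoro in place of hydrogen on this aromatic carbon, ortho to a large group, gives a 1.7-fold higher number from compound 2 to compound 3 (0.24 log units; within the scatter) and so stays within the scatter. Going by these compounds alone, with that fluoro already present, chloro in place of hydrogen gives a 2.1-fold higher number from compound 1 to compound 3 (0.32 log units; beyond the scatter) and is a modest step beyond the scatter, the only step here that clearly separates two compounds. Nothing measured here explains either step.

On these data alone, whether a nitrile, a methoxy group or an amine on the same carbon would behave like fluoro remains open.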